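Estimating a Small Silicon-Bearing Replacement for 4-Methylphenyl

The source may report more compounds than this note shows. Statements on the series, on what has been measured and on what is new or still open speak of the compounds shown alone.

Compound 1 `O=C1O[C@H]([C@@H](O)Cn2cc(-c3ccc(Br)cc3)nn2)C(OCc2ccccc2)=C1OCc1ccccc1` gives 5620 nM in a functional assay on MCF7 cells (Homo sapiens) for antiproliferative activity, read by MTT assay, with a stated time of 72 h; a lower number here means a stronger inhibitor, a higher number a weaker inhibitor
Compound 2 `Cc1ccc(-c2cn(C[C@H](O)[C@H]3OC(=O)C(OCc4ccccc4)=C3OCc3ccccc3)nn2)cc1` gives > 100000 nM as a limit of the assay, not a number

Compound 2 sits at the limit of > 100000 nM in this assay, at which 1 of the 2 values shown sits, and so has no exact place on the scale. Compound 3 `C[Si](C)(C)c1cn(C[C@H](O)[C@H]2OC(=O)C(OCc3ccccc3)=C2OCc2ccccc2)nn1` carries one change from compound 2 (a group of 4 heavy atoms (3 carbon, 1 silicon; no ring) in place of a group of 7 heavy atoms (7 carbon; one six-membered aromatic ring of carbon only), on an aromatic carbon) and the entering group has no common name. Among the measured compounds shown here, the only measured step of an at least 17-fold higher number from compound 1 to compound 2 (1.25 log units; beyond the scatter) is large and shows that a change on the six-membered aromatic ring can matter in this assay but here the whole ring leaves, so it guides only loosely. The expected step of an at least 1.6-fold lower number from compound 2 to compound 3 (0.22 log units; that floor lies within the scatter) is modest and points toward lower numbers, though another limit is quite possible. In this assay the estimate for compound 3 is 60000 nM with an expected range of 12000 nM to 100000 nM at this stage.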

Compound 3, half-maximal inhibitory concentration: 12100 nM
The estimate for compound 3 lay 5.0-fold (0.70 log units) above the measured number; low and high end bracket the measured number.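

A ring is not needed on this carbon to keep a measurable effect in this assay: the step is an at least 8.2-fold lower number from compound 2 to compound 3 (0.91 log units; beyond the scatter) and the ring-free silicon group restores a real number. That step has only a floor, since compound 2 is a limit of the assay and not a number: the limit of > 100000 nM in this assay, at which 1 of the 3 values shown sits. The same group still falls modestly short of the bromo-bearing ring, with a 2.2-fold higher number from compound 1 to compound 3 (0.33 log units; beyond the scatter) in the weaker direction. Whether silicon itself matters stays open, since a tert-butyl group, its all-carbon counterpart, is not among these compounds. How an amine or a longer chain would behave on this carbon is equally unknown.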